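The source may hold more compounds than are shown below. What is called first, only, known or untested is meant among the compounds shown, and "the series" means these compounds.

Measured in a functional assay on DU-145 cells (Homo sapiens) for antiproliferative activity, read by MTT assay, with a stated time of 48 h; a lower number here means a stronger inhibitor, a higher number a weaker inhibitor:
compound 1 `C/C(=C\CC/C(C)=C/CC[C@@H]1[C@@]2(C)CCC(=O)C(C)(C)[C@H]2CC[C@@]1(C)O)CC/C=C(\C)C(=O)OCc1cn(-c2ccccc2[N+](=O)[O-])nn1`: > 150000 nM, a limit of the assay
compound 2 `C/C(=C\CC/C(C)=C/CC[C@@H]1[C@@]2(C)CCC(=O)C(C)(C)[C@H]2CC[C@@]1(C)O)CC/C=C(\C)C(=O)OCc1cn(-c2ccc(Br)cc2)nn1`: > 150000 nM, a limit of the assay
compound 3 `C/C(=C\CC/C(C)=C/CC[C@@H]1[C@@]2(C)CCC(=O)C(C)(C)[C@H]2CC[C@@]1(C)O)CC/C=C(\C)C(=O)OCc1cn(-c2cccc(Cl)c2)nn1`: 103000 nM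

Among the compounds with values here, compound 3 carries the only actual number. The other two results are limits, as recorded in the limit of > 150000 nM in this assay, at which 2 of the 3 values shown sit.

Compound 4 `C/C(=C\CC/C(C)=C/CC[C@@H]1[C@@]2(C)CCC(=O)C(C)(C)[C@H]2CC[C@@]1(C)O)CC/C=C(\C)C(=O)OCc1cn(-c2ccccc2)nn1` has hydrogen in place of chloro on an aromatic carbon, meta to a large group: hydrogen in place of chloro on an aromatic carbon.

Within the data shown here, no measured step removes a substituent from the aryl ring outright. The closest evidence is the substituent swaps, an at least 1.4-fold lower number from compound 1 to compound 3 (0.16 log units; that floor lies within the scatter) and an at least 1.4-fold lower number from compound 2 to compound 3 (0.16 log units; that floor lies within the scatter). Each gives only a floor, and that floor lies within the scatter. The remaining swap is no help: a step that the two limits leave unreadable from compound 1 to compound 2.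

These steps give no ground for expecting a large move from compound 3 at 103000 nM. The expected step is a 1.3-fold higher number from compound 3 to compound 4 (0.10 log units; within the scatter), which means no clear change beyond the scatter, though a result reported only as a limit is quite possible.

For compound 4 the estimated value is 130000 nM, with an expected range of 70000 nM to 250000 nM.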

Compound 4, half-maximal inhibitory concentration: 95500 nM
Beside the measured number, compound 4's estimate is 1.4-fold (0.13 log units) above it, and the stated range covers the measured number.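

In this assay, the chloro on the aromatic carbon, meta to a large group, now has a direct reading: a 1.1-fold lower number from compound 3 to compound 4 (0.03 log units; within the scatter). Hydrogen in place of chloro therefore leaves the number within the scatter, and the measurable result of compound 3 does not depend on that chloro. The comparisons with the nitro and bromo compounds, an at least 1.5-fold lower number from compound 1 to compound 4 (0.19 log units; that floor lies within the scatter) and an at least 1.5-fold lower number from compound 2 to compound 4 (0.19 log units; that floor lies within the scatter), give only floors, and they rest on a limit of the assay: the limit of > 150000 nM in this assay, at which 2 of the 4 values shown sit.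

On these data alone, how far compound 1 and compound 2 truly lie from compound 4 stays open. Also open, as far as these compounds go, is whether an amine or a carboxylic acid on the aromatic ring, meta to a large group, would move the number beyond the scatter.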